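This account rests on a few compounds, and the source may have more. Where it says the series, first, only, none or still open, it means among the compounds named here.

Of the compounds shown here, three that share one core have been measured in a functional assay on L1210 cells (Mus musculus) for antiproliferative activity, read by cell counting, with a stated time of 96 h; a higher number here means a weaker inhibitor, a lower number a stronger inhibitor. Compound 1 `CC(=O)c1ccc(Oc2ccccc2NC(C)=C2C(=O)CC(c3ccccc3)CC2=O)cc1` gives 190 nM, the highest of the three numbers. Compound 2 `COc1ccc(Oc2ccccc2NC(C)=C2C(=O)CC(c3ccccc3)CC2=O)cc1` gives 140 nM, and compound 3 `CC(Nc1ccccc1Oc1ccc(C(C)O)cc1)=C1C(=O)CC(c2ccccc2)CC1=O` gives 58 nM. The step of a 1.4-fold lower number from compound 1 to compound 2 (0.13 log units; within the scatter) stays within the scatter, whereas a 3.3-fold lower number from compound 1 to compound 3 (0.52 log units; beyond the scatter) and a 2.4-fold lower number from compound 2 to compound 3 (0.38 log units; beyond the scatter) are modest but beyond it.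

The account now turns to compound 4 `COc1cccc(Oc2ccccc2NC(C)=C2C(=O)CC(c3ccccc3)CC2=O)c1`, which has not yet been measured. Compared with compound 1 it carries 3-methoxyphenyl in place of 4-acetylphenyl on an oxygen on an aromatic ring. Within the data shown here, the measured step that bears on this change is the one from compound 1 to compound 2, where a methoxy group likewise replaced an acetyl group on an aromatic carbon; that step, a 1.4-fold lower number from compound 1 to compound 2 (0.13 log units; within the scatter), did not leave the scatter. Among the measured compounds shown here, no measured pair sets a 3-methoxyphenyl group against the group that compound 2 carries, so the data give no ground for a larger shift in either direction. Compound 4 is therefore expected to show a 1.3-fold lower number from compound 1 to compound 4 (0.10 log units; within the scatter) in this assay, a step not beyond the scatter. The estimate for compound 4 is 150 nM, with a range from 60 nM to 400 nM.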

Compound 4, half-maximal inhibitory concentration: 58 nM
Compound 4: middle estimate off by 2.6-fold (0.41 log units), on the high side; measured number outside the range, below it.
By their numbers in this assay, from the lowest: compounds 3 and 4 (each within the scatter of the next); then compounds 2 and 1 (each within the scatter of the next).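

In this assay, among these compounds, the earlier compounds gave no sign that the place of a methoxy group on this ring could matter, yet setting a 3-methoxyphenyl group where a 4-methoxyphenyl group stood gives a step beyond the scatter (a 2.4-fold lower number from compound 2 to compound 4 (0.38 log units; beyond the scatter)). The direct change from 4-acetylphenyl to 3-methoxyphenyl likewise leaves the scatter (a 3.3-fold lower number from compound 1 to compound 4 (0.52 log units; beyond the scatter)), whereas the step from compound 1 to compound 2 did not, so exchanging acetyl for methoxy does not by itself settle the outcome at this ring. With 3-methoxyphenyl in place of 4-(1-hydroxyethyl)phenyl the reading does not move (no change at the digits printed from compound 3 to compound 4 (within the scatter)), so two differently substituted rings share the low end of this set, and no measurement at hand accounts for that.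

The compounds shown leave open whether the shift seen with 3-methoxyphenyl carries over to other groups on this ring, such as an amine, a carboxylic acid or a longer ether chain, or how a plain phenyl on the oxygen would compare. They also leave open whether compound 3 and compound 4 stay level in any test other than this assay.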